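Small Methoxy in Place of a Bulky Ketone Side Group

The source may report more compounds than this note shows. Statements on the series, on what has been measured and on what is new or still open speak of the compounds shown alone.

Compound 3 `CC(C)(C)C(=O)c1coc(C(=O)CCCCCCc2ccccc2)n1` holds the highest number of the two measured values in an assay on HEK-293T cells for inhibition of diacylglycerol lipase-alpha (Homo sapiens), read by colorimetric assay (a lower number here means a stronger inhibitor, a higher number a weaker inhibitor), giving 479 nM. Compound 2 `CC(=O)c1coc(C(=O)CCCCCCc2ccccc2)n1` gives 123 nM in this assay. Compound 1 `O=C(CCCCCCc1ccccc1)c1nnn[nH]1` reaches only a limit of the assay, > 10000 nM; > 10000 nM (2 entries). Compound 4 `COc1coc(C(=O)CCCCCCc2ccccc2)n1` differs from compound 3 by methoxy in place of (tert-butyl)carbonyl on an aromatic carbon. A single measured step touches this spot: a 3.9-fold higher number from compound 2 to compound 3 (0.59 log units; beyond the scatter) went toward a higher number when the group on the carbonyl carbon changed from methyl to tert-butyl. Among the measured compounds shown here, no measured pair shows what removing the carbonyl itself does, so that half of the change is untested. The step of a 1.2-fold lower number from compound 3 to compound 4 (0.08 log units; within the scatter) is therefore expected to be small and uncertain in direction. Compound 4 is expected to give about 400 nM, with a range from 80 nM to 2500 nM.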

Compound 4, half-maximal inhibitory concentration: > 10000 nM
Compound 4 ended at the assay's limit; the forecaster's own chance of this, stated with the estimate: 10%; at least 25-fold (1.39 log units) between middle value and limit.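

In this assay compound 4 gives > 10000 nM as a limit of the assay and not as a number. Methoxy in place of (tert-butyl)carbonyl brings an at least 20-fold higher number from compound 3 to compound 4 (1.31 log units; beyond the scatter) and methoxy in place of acetyl brings an at least 81-fold higher number from compound 2 to compound 4 (1.91 log units; beyond the scatter) on the same aromatic carbon. Among these compounds, then, replacing the whole carbonyl group at this position matters far more than changing the group on the carbonyl carbon.

From the compounds shown here alone, whether the loss follows from removing the carbonyl or from adding methoxy stays open. An amide or a carboxylic acid at this position could help separate the two.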